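This account rests on a few compounds, and the source may have more. Where it says the series, first, only, none or still open, it means among the compounds named here.

In a functional assay on A549 cells (Homo sapiens) for cytotoxicity, read by MTT assay; on this read-out lower numbers stand for stronger inhibition and higher numbers for weaker inhibition:
Compound 1 `N#Cc1c(Nc2ccccc2)c(Cl)c2nc(N)nc(N)c2c1F`: > 1000 ug/mL, a limit.
Compound 2 `N#Cc1c(NCc2ccccc2)c(Cl)c2nc(N)nc(N)c2c1F`: 34.1 ug/mL.
Compound 3 `N#Cc1c(NCc2ccccc2)c(F)c2nc(N)nc(N)c2c1F`: > 1000 ug/mL, a limit.

For the measured compounds named here, compound 2 holds the only true number in this set, and the other two results are limits, as the limit of > 1000 ug/mL in this assay, at which 2 of the 3 values shown sit, records. Compound 4 `CCN(CC)c1c(C#N)c(F)c2c(N)nc(N)nc2c1Cl` shares the core of compound 2 and differs in one group: diethylamino in place of benzylamino on an aromatic carbon. Going by the values given here, two measured steps bear on this. The more direct one, an at least 29-fold lower number from compound 1 to compound 2 (1.46 log units; beyond the scatter), changed the group on the same nitrogen, while an at least 29-fold higher number from compound 2 to compound 3 (1.46 log units; beyond the scatter) put fluoro in place of chloro. Both are large and beyond the scatter, and both neighbours of compound 2 sit at the limit, so a sizeable move towards a higher number is expected. The expected change is a 4.4-fold higher number from compound 2 to compound 4 (0.64 log units; beyond the scatter). For compound 4 the estimated value is 150 ug/mL, with an expected range from 30 ug/mL to 1000 ug/mL.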

Compound 4, half-maximal inhibitory concentration: 7.1 ug/mL
For compound 4 the middle estimate is 21-fold (1.32 log units) above the measured one; the measured number lies below the stated range.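

The earlier compounds shown here carried only an aromatic ring on this nitrogen, whereas diethylamino, with no ring and no hydrogen-bond donor, gives a 4.8-fold lower number from compound 2 to compound 4 (0.68 log units; beyond the scatter) and shows that such a ring is not needed for a measured number at this position. Against anilino, the same group gives an at least 140-fold lower number from compound 1 to compound 4 (2.14 log units; beyond the scatter) as a further step. Compound 1 is a limit, so that step is only a bound, because it rests on a value that is not a true number: the limit of > 1000 ug/mL in this assay, at which 2 of the 4 values shown sit.

Going by these compounds, it remains open how dimethylamino, dipropylamino or morpholine would read at this position. On these data alone, it is also open whether fluoro in place of chloro would raise the number with diethylamino as it did with benzylamino.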